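This account rests on a few compounds, and the source may have more. Where it says the series, first, only, none or still open, it means among the compounds named here.

Of the compounds shown here, three built on one shared core have been tested in an ADME assay on MDCK cells (Canis lupus familiaris) for cytotoxicity, with a stated time of 48 h; a higher number here means that more compound is tolerated, a lower number that less compound is tolerated. Compound 1 `CC(C)OCCCNC(=O)c1csc(Nc2ccc(Cl)c(Cl)c2)n1` gives 100000 nM. For compound 2 `CC(C)OCCCNC(=O)c1csc(Nc2ccc(Cl)cc2)n1` the result is only a limit, > 100000 nM. For compound 3 `CCOCCCNC(=O)c1csc(Nc2ccc(Cl)cc2)n1` the result is likewise a limit, > 100000 nM. Compound 2 thus stands at a limit rather than at a number, and so does one of the two further values shown. The step from compound 1 to compound 2, a number no lower from compound 1 to compound 2 (the limit leaves the size open), shows a value no lower for compound 2, but its size cannot be read. The step from compound 2 to compound 3, a step that the two limits leave unreadable from compound 2 to compound 3, cannot be read at all, since the limit of > 100000 nM in this assay, at which 2 of the 3 values shown sit, covers both of its ends.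

Compound 4 `Cc1cc(Nc2nc(C(=O)NCCCOC(C)C)cs2)ccc1Cl` differs from compound 2 by methyl in place of hydrogen on an aromatic carbon, so that 4-chlorophenyl becomes 4-chloro-3-methylphenyl. Neither measured step concerns a methyl entering an aromatic ring, and neither has a readable size, so in this assay no change beyond the scatter is expected. The expected step is a number no higher from compound 2 to compound 4 (the limit leaves the size open). Compound 4 is therefore expected to give 100000 nM, within a range from 50000 nM to 200000 nM, and most probably again only as a limit.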

Compound 4, half-maximal cytotoxic concentration: > 100000 nM
Compound 4 was reported as a limit; the forecaster's own chance of this, stated with the estimate: 70%; the middle value sits exactly at the limit.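

In this assay compound 4 gives > 100000 nM, which is a limit of the assay and not a number. This result adds a methyl on the aromatic carbon ortho to a chloro group, and set against compound 1, which carries a second chloro at that place, the change from chloro to methyl gives a number no lower from compound 1 to compound 4 (the limit leaves the size open). The change from hydrogen to methyl, like the other steps between two limits, cannot be read, since both ends of each such step lie beyond the range of the assay: the limit of > 100000 nM in this assay, at which 3 of the 4 values shown sit.

From the compounds shown here alone, how far compound 2, compound 3 and compound 4 lie past that limit remains unknown, so any effect of the hydrogen-to-methyl change on tolerated concentration stays hidden. Also open, going by these compounds, is whether a different group at this aromatic carbon, such as an amine, a carboxylic acid or a longer chain, would bring the result down to a readable number.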